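The source may report more compounds than this note shows. Statements on the series, on what has been measured and on what is new or still open speak of the compounds shown alone.

Of the compounds shown here, three have been tested so far in a functional assay on A549 cells (Homo sapiens) for antiproliferative activity, read by MTT assay, with a stated time of 48 h; a lower number here means a stronger inhibitor, a higher number a weaker inhibitor. Compound 1 `Cn1cc(-c2cnc3ccc(NCc4ccc(F)cc4)nc3c2)cn1` gives > 50000 nM, which is a limit and not a number. Going by the values given here, compound 2 `Cn1cc(-c2cnc3ccnc(NCc4ccc(F)cc4)c3c2)cn1` gives 5200 nM, the one true number in this small set. Compound 3 `Cc1ccc(S(=O)(=O)Nc2nccc3ncc(-c4cnn(C)c4)cc23)cc1` gives > 50000 nM, which is again a limit and not a number. Compound 3 therefore stands at the limit of > 50000 nM in this assay, at which 2 of the 3 values shown sit.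

The next compound to consider is compound 4 `Cn1cc(-c2cnc3ccnc(NS(=O)(=O)c4c(Cl)cccc4Cl)c3c2)cn1`. It keeps the shared core and the sulfonamide nitrogen of compound 3, but it carries 2,6-dichlorophenyl in place of 4-methylphenyl on a sulfonyl sulfur. The two groups are close in size by this count, and each is one six-membered aromatic ring of carbon only. Among the compounds with values here, no measured pair in this set shows what such an exchange does, so any forecast is uncertain.

The expectation starts from compound 3, whose > 50000 nM is a limit. Only a small gain in potency is expected in this assay, an estimated at least 1.6-fold lower number from compound 3 to compound 4 (0.22 log units; that floor lies within the scatter). A report of a limit alone would also be no surprise. For compound 4 the expected value is 30000 nM, with an estimated range from 6000 nM to 50000 nM.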

Compound 4, half-maximal inhibitory concentration: > 50000 nM
Compound 4 was reported as a limit (the forecaster's own chance of this, stated with the estimate: 55%); at least 1.6-fold (0.22 log units) between middle value and limit.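

In this assay compound 4 gives > 50000 nM, which is a limit and not a number. Going by these compounds alone, compound 3 also stands at a limit, so no step from compound 3 to compound 4 can be read: the limit of > 50000 nM in this assay, at which 3 of the 4 values shown sit. The compounds shown leave open whether 2,6-dichlorophenyl in place of 4-methylphenyl on a sulfonyl sulfur changes potency at all.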